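Fluorophenyl sulfonyl quinolines: removing one fluoro, clearance expected

The compounds below may be only part of what the source reports. "The series", "measured", "known", "first", "only" and "open" are said of these compounds alone.

Compound 1 `O=S(=O)(c1cc(F)cc(F)c1)c1cnc2c(F)cccc2c1-c1cccc(Cl)c1` and compound 2 `O=S(=O)(c1cccc(F)c1)c1cnc2c(F)cccc2c1-c1cccc(Cl)c1` share one core and differ by hydrogen in place of fluoro on an aromatic carbon. In an ADME assay on microsomes from liver (Homo sapiens) for metabolic stability, tested at 2.5 uM (on this read-out higher numbers stand for fast clearance and lower numbers for slow clearance), compound 1 gives 0.64 mL/min, and compound 2 gives 0.56 mL/min, a step of a 1.1-fold lower number from compound 1 to compound 2 (0.06 log units; within the scatter). Compound 3 `O=S(=O)(c1ccc(F)c(F)c1)c1cnc2cc(F)ccc2c1-c1ccc(Cl)cc1` stands on a different core; how the two cores differ is not broken down here. In this assay compound 3 gives 0.01 mL/min, the lowest number of the three measured compounds, its steps to compound 1 and to compound 2 both lying beyond the scatter. Compound 4 `O=S(=O)(c1cccc(F)c1)c1cnc2cc(F)ccc2c1-c1ccc(Cl)cc1` has not yet been measured and differs from compound 3 by hydrogen in place of fluoro on an aromatic carbon. This is the same kind of change as that from compound 1 to compound 2, but not the same: in the earlier pair the hydrogen enters meta to a fluoro group and meta to a large group, whereas here it enters ortho to a fluoro group and para to a large group. Because the step of a 1.1-fold lower number from compound 1 to compound 2 (0.06 log units; within the scatter) lay within the scatter, a step of similar size is expected here, estimated as a 1.2-fold higher number from compound 3 to compound 4 (0.08 log units; within the scatter). Compound 4 is thus expected to give 0.012 mL/min in this assay, estimated between 0.004 mL/min and 0.04 mL/min.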

Compound 4, intrinsic clearance in a liver preparation (reported as CLH), per the amount of preparation that the assay uses: 0.98 mL/min
Beside the measured number, compound 4's estimate is 82-fold (1.91 log units) below it; measured number above the stated range.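

The removal of one fluoro does not carry from one core to the other in this assay: the same change on two cores in this assay, a 1.1-fold lower number (0.06 log units; within the scatter) from compound 1 to compound 2 and a 98-fold higher number (1.99 log units; beyond the scatter) from compound 3 to compound 4, 110-fold (2.05 log units) apart, beyond the scatter of two such steps. On the core of compound 3, the change from 3,4-difluorophenyl to 3-fluorophenyl gives a 98-fold higher number from compound 3 to compound 4 (1.99 log units; beyond the scatter), so the near-flat step on the core of compound 1 is no guide to the size of this change elsewhere in the series. This does not show which feature of the cores sets the gap, since the fluoro also leaves a different place in each pair, and a single pair per core gives no rule for either core.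

The compounds shown hold only fluoro or hydrogen at the aromatic carbon that changes, so it stays open how a chloro, methyl or methoxy group would read there in the same assay. Also open, as far as these compounds go, is whether a third core would follow compound 1 and compound 2, follow compound 3 and compound 4, or fall somewhere else.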